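The compounds below may be only part of what the source reports. "The series", "measured", "known", "first", "only" and "open" are said of these compounds alone.

Compound 2 `O=C1N=C(N2CCC[C@H]2C(=O)Nc2ccc3ncnc(Nc4cccc(Cl)c4)c3c2)S/C1=C/c1ccc(-c2ccccc2)cc1` gives 15400 nM in a functional assay on HepG2 cells (Homo sapiens) for antiproliferative activity, read by MTT assay (a higher number here means a weaker inhibitor, a lower number a stronger inhibitor), the higher of the two numbers recorded; compound 1 `Cc1cccc(/C=C2/SC(N3CCC[C@H]3C(=O)Nc3ccc4ncnc(Nc5cccc(Cl)c5)c4c3)=NC2=O)n1` gives 4500 nM. Compound 3 `O=C1N=C(N2CCC[C@H]2C(=O)Nc2ccc3ncnc(Nc4cccc(Cl)c4)c3c2)S/C1=C/c1ccccc1Br` carries 2-bromophenyl in place of 4-phenylphenyl on a double-bonded chain carbon bound to a double-bonded ring carbon. Among the compounds with values here, only one measured step bears on this, and loosely: a 3.4-fold higher number from compound 1 to compound 2 (0.53 log units; beyond the scatter), where a single six-membered ring was exchanged for the two-ring group now being removed. Since compound 1 with its single ring gave 4500 nM, returning to a single ring is expected to bring a modest step back toward lower numbers, estimated as a 2.4-fold lower number from compound 2 to compound 3 (0.37 log units; beyond the scatter), though a different ring is a real uncertainty. For compound 3 the expected value is 6500 nM, within 2000 nM to 20000 nM.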

Compound 3, half-maximal inhibitory concentration: 24300 nM
Beside the measured number, compound 3's estimate is 3.7-fold (0.57 log units) below it, outside the stated range (above it).
By their numbers in this assay, from the lowest: compound 1; then compounds 2 and 3 (each within the scatter of the next).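

In this assay, 2-bromophenyl in place of 4-phenylphenyl gives a 1.6-fold higher number from compound 2 to compound 3 (0.20 log units; within the scatter) and so leaves these two groups indistinguishable, which means that a single ring in place of two is not enough here to reach the number of compound 1. Set against 6-methylpyridin-2-yl, the same 2-bromophenyl gives a 5.4-fold higher number from compound 1 to compound 3 (0.73 log units; beyond the scatter) and so, of the three groups, only the one in compound 1 stands apart. No available evidence explains this difference. As far as these compounds go, whether the ring nitrogen or the methyl of 6-methylpyridin-2-yl matters stays open. So does the effect of an unsubstituted phenyl or a phenyl carrying an amine at this place.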